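From phenyl to tert-butylphenoxy: expected acid dissociation

The source may report more compounds than this note shows. Statements on the series, on what has been measured and on what is new or still open speak of the compounds shown alone.

Compound 1, `COc1ccc(Oc2ccc3c(NCCCNCc4cccc(OC)c4O)ccnc3c2)cc1`, gives 9.28.
Compound 2, `COc1cccc(CNCCCNc2ccnc3cc(Cc4ccccc4)ccc23)c1O`, gives 9.47.
Compound 3, `COc1cccc(CNCCCNc2ccnc3cc(-c4ccccc4)ccc23)c1O`, gives 9.47.

All three numbers come from a physicochemical assay for acid dissociation. Compound 3 stands level with compound 2 at the digits shown; together they are the highest of the three numbers, and the gap to compound 1 is within the scatter. Compound 4, `COc1cccc(CNCCCNc2ccnc3cc(Oc4ccc(C(C)(C)C)cc4)ccc23)c1O`, has not yet been measured. It differs from compound 3 in one place: 4-(tert-butyl)phenoxy in place of phenyl on an aromatic carbon. The group sits on an aromatic carbon of a six-membered aromatic ring of carbon only, part of a fused or bridged system of two rings, meta to a fused ring and para to a fused ring.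

Within the data shown here, two measured steps bear on this change, both at the same position. The step of a number 0.19 log units higher from compound 1 to compound 3 (within the scatter) replaces a phenoxy-type group by phenyl, and a number 0.19 log units higher from compound 1 to compound 2 (within the scatter) by benzyl; neither leaves the scatter. Going the other way, from phenyl to a substituted phenoxy, no step beyond the scatter in this assay is therefore expected, with at most a slight drift downward.

Compound 4 is thus estimated at 9.33, within 9 to 9.65, which means an expected step of a number 0.14 log units lower from compound 3 to compound 4 (within the scatter).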

Compound 4, acid dissociation constant: 9.28
The estimate for compound 4 lay 0.05 log units above the measured number; low and high end bracket the measured number.
By their numbers in this assay, from the lowest: compounds 1, 4, 2 and 3 (each within the scatter of the next).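

In this assay, 4-(tert-butyl)phenoxy at this aromatic carbon, in place of phenyl, gives a number 0.19 log units lower from compound 3 to compound 4 (within the scatter), and in place of benzyl gives a number 0.19 log units lower from compound 2 to compound 4 (within the scatter), so a much larger group carrying an ether oxygen and a branched alkyl substituent still leaves the read-out within the scatter of both. Among these compounds, the comparison with compound 1 adds something the earlier compounds could not show, a change on the outer ring of the phenoxy group itself: tert-butyl in place of methoxy gives no change at the digits printed from compound 1 to compound 4 (within the scatter). No accompanying measurement speaks to what lies behind these numbers.

All four groups at this position are built on a ring of carbon only with no charge, so the compounds shown leave open whether a group of another kind here, such as an aminomethyl group or a carboxylic acid, would move the number in this assay beyond the scatter. They also leave open whether a dimethylamino group or a carboxylic acid on the outer ring of the phenoxy group, in place of tert-butyl, would do so.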